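Compound 1 and its carboxy counterpart

This account rests on a few compounds, and the source may have more. Where it says the series, first, only, none or still open, it means among the compounds named here.

Compound 1 `COC(=O)c1nn([C@@H]2O[C@H](CO)[C@@H](O)[C@H]2O)cc1I` gives 1500 nM
Compound 2 `C#Cc1cn([C@@H]2O[C@H](CO)[C@@H](O)[C@H]2O)nc1C(N)=O` gives > 300000 nM (a limit)

Among the measured compounds shown here, in a functional assay on CCRF-CEM cells (Homo sapiens) (a higher number here means a weaker inhibitor, a lower number a stronger inhibitor), compound 1 gives 1500 nM as the only actual number so far. For compound 2 the assay reports > 300000 nM, which is a limit and not a number.

The next compound is compound 3 `O=C(O)c1nn([C@@H]2O[C@H](CO)[C@@H](O)[C@H]2O)cc1I`, the carboxy counterpart of compound 1. The change is methoxycarbonyl to carboxy, with hydrogen in place of methyl on an oxygen next to a carbonyl group. The rest of the core of compound 1 stays as it is.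

For the measured compounds named here, no step between measured compounds is available to size this change, so the expectation rests on the structural change alone. A large step towards weaker inhibition in this assay is expected, well beyond the scatter, and a reading that stops at the limit of the assay remains a real possibility. The expected change is a 40-fold higher number from compound 1 to compound 3 (1.60 log units; beyond the scatter) in size. For compound 3 the estimate is 60000 nM, with an expected range from 8000 nM to 300000 nM.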

Compound 3, half-maximal inhibitory concentration: > 300000 nM
Compound 3 was reported as a limit; the forecaster's own chance of this, stated with the estimate: 45%; middle value at least 5.0-fold (0.69 log units) from the limit.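

Among the compounds shown here, replacing methyl with hydrogen on an oxygen next to a carbonyl group, which turns methoxycarbonyl into carboxy, gives the first change that differs in one place, and in this assay it produces an at least 200-fold higher number from compound 1 to compound 3 (2.30 log units; beyond the scatter). For compound 3 the reading of > 300000 nM is a limit of the assay and not a number. The loss of a single methyl, one heavy atom, is thus enough to move this position from a measured value to the end of the readable range, but the full size of the step cannot be given because the reading stops at that limit: the limit of > 300000 nM in this assay, at which 2 of the 3 values shown sit.

The compounds shown leave open whether the methyl itself matters or only the cap on the oxygen, as a longer chain such as ethyl or benzyl on that same oxygen would show. They also leave open how a nitrile or a hydroxymethyl group would read in place of the methoxycarbonyl while the rest of the core of compound 1 stays as it is.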